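Aminomethyl chain in place of the aldehyde in compound 3

The source may hold more compounds than are shown below. What is called first, only, known or untested is meant among the compounds shown, and "the series" means these compounds.

Three members of the stilbene series carry the same shared core and differ only in the group on the benzylic ether ring. Compound 1 `COc1ccc(/C=C\c2cc(OC)c(OC)c(OC)c2)cc1OCc1ccc(CN2CC[C@H](C(=O)O)C2)cc1` gives in a functional assay on MC-38 cells (Mus musculus) for antiproliferative activity, read by CCK-8 assay, with a stated time of 48 h (a lower number here means a stronger inhibitor, a higher number a weaker inhibitor), a value that is a limit of the assay, > 10000 nM. Compound 2 `COc1ccc(/C=C\c2cc(OC)c(OC)c(OC)c2)cc1OCc1ccc(CN2CCCCC2C(=O)NCCN)cc1` also returns a limit in this assay, > 10000 nM. Among the compounds with values here, compound 3 `COc1ccc(/C=C\c2cc(OC)c(OC)c(OC)c2)cc1OCc1ccc(C=O)cc1` is the one member with a number, 900 nM, and so stands as the only measured point to build from. The step with formyl in place of (3-carboxypyrrolidin-1-yl)methyl on an aromatic carbon gave an at least 11-fold lower number from compound 1 to compound 3 (1.04 log units; beyond the scatter), while a step that the two limits leave unreadable from compound 1 to compound 2 stays unreadable because of the limit of > 10000 nM in this assay, at which 2 of the 3 values shown sit.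

Compound 4 `COc1ccc(/C=C\c2cc(OC)c(OC)c(OC)c2)cc1OCc1ccc(CNCCN(C)C)cc1` carries the change (((2-(dimethylamino)ethyl)amino)methyl in place of formyl on an aromatic carbon). Within the data shown here, this moves back toward the substituted-methyl pattern of compound 1 and compound 2, so an upward step is expected rather than none; the only readable step, an at least 11-fold lower number from compound 1 to compound 3 (1.04 log units; beyond the scatter), sets its rough size. The estimated step is a 3.9-fold higher number from compound 3 to compound 4 (0.59 log units; beyond the scatter). Compound 4 is therefore expected at 3500 nM, within 700 nM to 15000 nM.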

Compound 4, half-maximal inhibitory concentration: 1400 nM
Beside the measured number, compound 4's estimate is 2.5-fold (0.40 log units) above it, within the range that was stated.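

The step to ((2-(dimethylamino)ethyl)amino)methyl in place of formyl in this assay reads a 1.6-fold higher number from compound 3 to compound 4 (0.19 log units; within the scatter), so on this aromatic carbon, para to a large group, the amine chain and the formyl group cannot be told apart. The same open chain also separates from the two ring-bearing groups on the saturated chain carbon, with an at least 7.1-fold lower number from compound 2 to compound 4 (0.85 log units; beyond the scatter) and an at least 7.1-fold lower number from compound 1 to compound 4 (0.85 log units; beyond the scatter). A substituted methyl group at this place therefore does not by itself bring the number to the limit of the assay.

The step between the two ring-bearing amines cannot be read: the limit of > 10000 nM in this assay, at which 2 of the 4 values shown sit. From the compounds shown here alone, how the number responds to a shorter chain ending in a primary amine, a morpholine on the same methyl carbon, or a hydroxymethyl group in place of formyl remains open.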